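This account rests on a few compounds, and the source may have more. Where it says the series, first, only, none or still open, it means among the compounds named here.

Compound 1 `N#Cc1ccc(-c2ccc(C(=O)Nc3ccc4cccnc4c3)cn2)cc1`, compound 2 `Cc1cc(-c2ccccc2)ncc1C(=O)Nc1ccc2cccnc2c1`, compound 3 `Cc1nc(-c2ccc(F)cc2)ccc1C(=O)Nc1ccc2ncsc2c1`.

In an in vitro functional assay on 1321-N1 cells for antagonist activity at transient receptor potential cation channel subfamily V member 1 (Homo sapiens), read by FLIPR and calcium flux (on this read-out higher numbers stand for higher potency (the scale is a negative logarithm) and lower numbers for lower potency), compound 2 gives 6.7. In this assay compound 3 gives 6.7. Compound 1 reaches only < 6.6 in this assay, which is a limit of the assay rather than a number. Among the three values shown, compound 1 is the one sitting at the limit of < 6.6 in this assay, at which 1 of the 3 values shown sits.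

Compound 4 `N#Cc1ccc(C(=O)Nc2ccc3cccnc3c2)cn1` differs from compound 1 by cyano in place of 4-cyanophenyl on an aromatic carbon. Going by the values given here, no measured pair shows a change of this kind, so its size is uncertain. Given that compound 1 sits at the limit of < 6.6 in this assay, at which 1 of the 3 values shown sits, the expected step that the limit leaves unreadable from compound 1 to compound 4 points toward lower potency, beyond the scatter. Compound 4 is expected to give about 5.9 in this assay, within 5.2 to 6.6, most likely again only a limit.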

Compound 4, negative logarithm of the antagonist equilibrium constant: < 6.7
Compound 4: no number, only a limit (the forecaster's own chance of this, stated with the estimate: 75%); the middle value does not contradict the limit.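

Compound 1 and compound 4 both give only limits in this assay, not numbers, so the step between them cannot be read. The compounds shown leave open how far potency shifts when cyano replaces 4-cyanophenyl.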